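Swapping the Chlorophenyl Rings on a Pyrazoline Core

A few compounds are considered here, and "the series" means these few. Any claim that something is new, unique, unknown or untested is made for them only; others in the source may bear on it.

Compound 2 `Oc1ccc(C2=NN(c3cccc(Cl)c3)C(c3cccc(Cl)c3)C2)cc1` stands highest of the two numbers shown: in an assay on HEK293 cells for inhibition of protein kinase C zeta type (Homo sapiens), read by 33P incorporation, with a stated time of 40 min, tested at 20 uM, in the presence of a further agent that is not named here (a higher number here means more inhibition at the concentration tested (going by the name of the read-out), a lower number less inhibition), compound 2 gives 85.7%, whereas compound 1 `Oc1ccc(C2=NN(c3ccc(Cl)cc3)C(c3cccc(Cl)c3)C2)cc1` gives 71.8%. The step of a number 13.9 percentage points higher from compound 1 to compound 2 (beyond the scatter) concerns the group on the amine nitrogen in the ring. Compound 3 `Oc1ccc(C2=NN(c3cccc(Cl)c3)C(c3ccc(Cl)cc3)C2)cc1` differs from compound 2 at a different place: 4-chlorophenyl in place of 3-chlorophenyl on a saturated ring carbon. Among the compounds with values here, no measured step addresses this saturated ring carbon, so the only guide is the modest size of the one known step. A small drop, hardly beyond the scatter, is expected for compound 3, namely a number 7.7 percentage points lower from compound 2 to compound 3 (within the scatter), giving an estimated 78% with a range from 60% to 92%.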

Compound 3, a percentage reported as inhibition, at one concentration (the size of the read-out at that concentration, not a potency): 86.2%
Estimate against measurement, compound 3: 8.2 percentage points below; measured number inside the range.
By their numbers in this assay, from the lowest: compound 1; then compounds 2 and 3 (each within the scatter of the next).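

In this assay, 4-chlorophenyl in place of 3-chlorophenyl on the saturated ring carbon gives a number 0.5 percentage points higher from compound 2 to compound 3 (within the scatter). The exchange between these two groups, which registered on the amine nitrogen in the ring, therefore does not register at this position. Nothing available accounts for this difference between the two positions.

From the compounds shown here alone, whether an amine or a carboxylic acid in place of the chlorine at this carbon's phenyl group would shift the number remains open. So does whether this position would stay as insensitive with 4-chlorophenyl on the amine nitrogen.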